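The compounds below may be only part of what the source reports. "The series", "measured", "known", "first", "only" and "open" are said of these compounds alone.

Measured compounds:
- compound 1 `Cc1ccc(-c2c(C)noc2C)cc1S(=O)(=O)NC1CCCC1`, in a functional assay on MT4 cells (Homo sapiens) for cytotoxicity, read by CellTiter-Glo, with a stated time of 5 days (a lower number here means that less compound is needed, a higher number that more compound is needed for the effect), compound 1 gives 1590 nM
- compound 2 `Cc1noc(C)c1-c1cc(-c2c(C3CC3)n[nH]c2C)c2[nH]c(C3CC3)nc2c1`, in this assay compound 2 gives 8 nM

Among the compounds with values here, of these two numbers, compound 1 stands highest; the only other value, that of compound 2, is far lower, and the gap between them lies well beyond the scatter. Within the data shown here, no step between measured compounds that differ in one place has been recorded, so the series itself gives no guide to the size of small changes.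

Compound 3 `Cc1ccc(-c2cnoc2C)cc1S(=O)(=O)NC1CCCC1` is not yet measured. It differs from compound 1 as hydrogen in place of methyl on an aromatic carbon. The change removes a single carbon on the five-membered ring while leaving the sulfonamide and the rest of the core untouched. With nothing to support a directed shift, the step from compound 1 to compound 3 in this assay is expected to be small, likely none beyond the scatter. For compound 3 the estimate is 1800 nM, with a range from 700 nM to 4500 nM, a step of a 1.1-fold higher number from compound 1 to compound 3 (0.05 log units; within the scatter).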

Compound 3, half-maximal effective concentration: 15100 nM
Compound 3: the middle estimate sits 8.4-fold (0.92 log units) below what was measured; measured number above the stated range.
By their numbers in this assay, from the lowest: compound 2; then compound 1; then compound 3.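

Going from the 3,5-dimethyl-1,2-oxazol-4-yl group to the 5-methyl-1,2-oxazol-4-yl group gives a 9.5-fold higher number from compound 1 to compound 3 (0.98 log units; beyond the scatter) in this assay and is the first one-place step in the series, lying beyond the scatter. This aromatic carbon, next to the ring nitrogen and next to the ring atom that bears a large group, is therefore not indifferent to its substituent in this pair: the loss of a single carbon, with no hydrogen-bond donor, acceptor or net charge involved in the change, moves the number upward. No measurement at hand speaks to the cause of this step.

On these data alone, whether an ethyl or an amine in place of this methyl would move the number in either direction remains open. Also open, as far as these compounds go, is whether the same removal would have a similar effect on the core of compound 2, which carries the same 3,5-dimethyl-1,2-oxazol-4-yl group.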